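A few compounds are considered here, and "the series" means these few. Any claim that something is new, unique, unknown or untested is made for them only; others in the source may bear on it.

Values in a functional assay on PC-3 cells (Homo sapiens) for cytotoxicity, read by MTT assay, with stated times of 48 h and 4 h; a higher number here means a weaker inhibitor, a lower number a stronger inhibitor:
- Compound 1 `COc1ccc(/C=C/c2nc(NCCN(C(C)C)C(C)C)c3ccccc3n2)cc1OC`: 20300 nM
- Compound 2 `COc1ccc(/C=C/c2nc(NCCN3CCCCC3)c3ccccc3n2)cc1OC`: 78500 nM
- Compound 3 `COc1ccc(/C=C/c2nc(NCCN(C(C)C)C(C)C)c3cc(Cl)ccc3n2)cc1OC`: > 100000 nM, a limit of the assay

Compound 3 gives only a limit, > 100000 nM, and no number.

Compound 4 `COc1ccc(/C=C/c2nc(NCCCCN)c3cc(Cl)ccc3n2)cc1OC` keeps the chloro group of compound 3 and alters the chain: 2-aminoethyl in place of diisopropylamino on a saturated chain carbon, two bonds along the chain from a nitrogen on an aromatic ring. Within the data shown here, two measured steps bear on this. The closer one also replaces diisopropylamino, there with piperidin-1-yl, and shows a 3.9-fold higher number from compound 1 to compound 2 (0.59 log units; beyond the scatter). The other, chloro in place of hydrogen, shows an at least 4.9-fold higher number from compound 1 to compound 3 (0.69 log units; beyond the scatter) and accounts for the starting point. Neither step tests a 2-aminoethyl group, so the direction remains uncertain. With compound 3 at > 100000 nM, the only room for a measurable result lies towards a lower number, and a modest step in that direction is expected, although compound 4 may also stay at the limit. The expected step is an at least 1.8-fold lower number from compound 3 to compound 4 (0.25 log units; that floor lies within the scatter). Compound 4 is estimated at 55000 nM, with an expected range of 15000 nM to 100000 nM.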

Compound 4, half-maximal inhibitory concentration: > 100000 nM
Compound 4 ended at the assay's limit; the forecaster's own chance of this, stated with the estimate: 35%; middle value at least 1.8-fold (0.25 log units) from the limit.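

In this assay, among these compounds, compound 3 and compound 4 both sit at a limit of the assay rather than at a number, so no step between them can be read: the limit of > 100000 nM in this assay, at which 2 of the 4 values shown sit. The compounds shown leave open how 2-aminoethyl compares with diisopropylamino at this place, with or without the chloro group.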